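From ethylsulfanyl to methoxy on a shared core

The source may report more compounds than this note shows. Statements on the series, on what has been measured and on what is new or still open speak of the compounds shown alone.

Of the compounds shown here, two have so far been measured in a functional assay on HT-29 cells (Homo sapiens) for inhibition, read by sulforhodamine B assay, with a stated time of 72 h (on this read-out higher numbers stand for weaker inhibition and lower numbers for stronger inhibition), and give these values.

Compound 1 (`COc1ccc(C2C(O)C(=O)N2c2cc(OC)c(OC)c(OC)c2)cc1`) gives (12 nM)
Compound 2 (`CCSc1ccc(C2C(Oc3ccccc3)C(=O)N2c2cc(OC)c(OC)c(OC)c2)cc1`) gives (632 nM)

Of the two, compound 2 has the higher number and so the weaker inhibition, and the gap down to compound 1 (12 nM) lies beyond the usual scatter.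

The next compound, compound 3 (`COc1ccc(C2C(Oc3ccccc3)C(=O)N2c2cc(OC)c(OC)c(OC)c2)cc1`), has not yet been measured. It differs from compound 2 in one place, on an aromatic carbon of a six-membered aromatic ring of carbon only, para to a large group, with methoxy in place of ethylsulfanyl (methoxy in place of ethylsulfanyl on an aromatic carbon). Among the compounds with values here, the 4-methoxyphenyl group also occurs in compound 1, but that compound differs from compound 3 elsewhere as well, so no measured pair shows this change alone.

The step expected in this assay is a moderate one toward stronger inhibition, estimated as a 4.2-fold lower number from compound 2 to compound 3 (0.62 log units; beyond the scatter) and probably beyond the scatter. For compound 3 an expected value of 150 nM is estimated, with a range from 30 nM to 700 nM as the likely span.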

Compound 3, half-maximal inhibitory concentration: 52 nM
Compound 3: the middle estimate sits 2.9-fold (0.46 log units) above what was measured; the measured number falls inside the stated range.
By their numbers in this assay, from the lowest: compound 1; then compound 3; then compound 2.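

In this assay, the change from 4-(ethylsulfanyl)phenyl to 4-methoxyphenyl can now be read alone, and it gives a 12-fold lower number from compound 2 to compound 3 (1.08 log units; beyond the scatter) with the rest of the structure held the same, so this aromatic carbon, para to a large group, is a place where the choice of group strongly alters the number. Compound 3 also links to compound 1 through a single change elsewhere, phenyl in place of hydrogen on an oxygen on a saturated carbon, which gives a 4.3-fold higher number from compound 1 to compound 3 (0.64 log units; beyond the scatter) with the 4-methoxyphenyl group held constant, so the two changes no longer have to be read together. Nothing measured here accounts for either step.

The compounds shown leave open whether the first step follows from the exchange of sulfur for oxygen or from the shorter chain; a methylsulfanyl or an ethoxy group at this place would separate the two. They also leave open whether the 4-(ethylsulfanyl)phenyl group behaves the same way on the core of compound 1, and how a benzyl group on that oxygen in place of phenyl would read.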